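The source may hold more compounds than are shown below. What is called first, only, known or untested is meant among the compounds shown, and "the series" means these compounds.

In an ADME assay on L929 cells (Mus musculus) for cytotoxicity, read by resazurin assay, with a stated time of 48 h (a higher number here means that more compound is tolerated, a lower number that less compound is tolerated), compound 1 `O=c1c2cc([N+](=O)[O-])ccc2n(CCCO)n1Cc1ccccc1` gives > 256000 nM, which is a limit of the assay and not a number. Compound 2 `COCCn1c2ccc([N+](=O)[O-])cc2c(=O)n1Cc1ccccc1` gives > 256000 nM, also a limit. Within the data shown here, compound 2 therefore has no numerical position, and the one other value shown is likewise a limit: the limit of > 256000 nM in this assay, at which 2 of the 2 values shown sit. Among the measured compounds shown here, the sole measured step is a step that the two limits leave unreadable from compound 1 to compound 2, so it offers no size to carry forward.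

Compound 3 `CC(=O)n1c2ccc([N+](=O)[O-])cc2c(=O)n1Cc1ccccc1` has acetyl in place of 2-methoxyethyl on an aromatic nitrogen, next to the ring atom that bears a benzyl group: acetyl in place of 2-methoxyethyl on an aromatic nitrogen. For the measured compounds named here, no measured step involves acetyl, so the size in this assay is poorly constrained. Little change is expected, with only a cautious lean toward less compound tolerated. The estimated change is an at least 1.3-fold lower number from compound 2 to compound 3 (0.12 log units; that floor lies within the scatter). For compound 3 the expected value is 190000 nM, with an estimated range from 70000 nM to 256000 nM.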

Compound 3, concentration lethal to 50% of the cells: > 256000 nM
Compound 3 ended at the assay's limit; the forecaster's own chance of this, stated with the estimate: 55%; middle value at least 1.3-fold (0.12 log units) from the limit.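

The steps from compound 3 to compound 1 and compound 2 cannot be read, since all three values are limits and not numbers: the limit of > 256000 nM in this assay, at which 3 of the 3 values shown sit.

The compounds shown leave open whether 3-hydroxypropyl, 2-methoxyethyl and acetyl on the aromatic nitrogen differ at all in this assay.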